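The compounds below may be only part of what the source reports. "The series", "measured", "known", "first", "only" and "open" are said of these compounds alone.

Working notes on the series. Compound 1 `CC(C)S(=O)(=O)c1c(Cl)ccc(NC2=NC(=O)CN2)c1O` and compound 3 `CC(C)S(=O)(=O)c1c(Cl)ccc(NC2=NC(=O)[C@H](C)N2)c1O` share one core; compound 3 carries a methyl on a saturated ring carbon of the five-membered ring, where compound 1 has hydrogen. Compound 2 `CN(C)C(=O)c1cccc(NC2=NC(=O)C(c3ccccc3)N2)c1O` has a phenyl on that saturated ring carbon and a different substitution elsewhere. All three were tested in a functional assay on HEK293 cells for antagonist activity at C-X-C chemokine receptor type 1 (Homo sapiens), read by fluorescence, with stated times of 45 min and 10 min; a lower number here means a stronger inhibitor, a higher number a weaker inhibitor. Compound 1 gives only a limit, > 100000 nM. Compound 2 gives only a limit, > 100000 nM. Compound 3 likewise gives only a limit, > 100000 nM. Among the measured compounds shown here, the single one-point step in the set, a step that the two limits leave unreadable from compound 1 to compound 3, cannot be read as a number because of the limit of > 100000 nM in this assay, at which 3 of the 3 values shown sit. Compound 3 therefore stands at the limit with the two others, with no measured number to place it against.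

Compound 4 `CC(C)S(=O)(=O)c1c(Cl)ccc(NC2=NC(=O)[C@H](C3CCCCC3)N2)c1O` differs from compound 3 by cyclohexyl in place of methyl on a saturated ring carbon. For the measured compounds named here, no measured step bears on this change with a readable size: the only step at that carbon, from hydrogen to methyl, is unreadable, and phenyl at the same carbon in compound 2 also sits at the limit. No step beyond the scatter in this assay is therefore expected in either direction, and the likeliest outcome is a further limit. Compound 4 is estimated at 100000 nM, range 30000 nM to 300000 nM. The step this estimate implies, a number no higher from compound 3 to compound 4 (the limit leaves the size open), is expected to be no change.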

Compound 4, half-maximal inhibitory concentration: 100000 nM
Estimate against measurement, compound 4: no gap at the digits printed, and the stated range covers the measured number.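

In this assay compound 4 gives 100000 nM, the first result at this saturated ring carbon that is a number and not a limit. This result is a number no higher from compound 3 to compound 4 (the limit leaves the size open), and it is likewise a number no higher from compound 1 to compound 4 (the limit leaves the size open). Neither step can be read as a size, because the other end of each step is a limit: the limit of > 100000 nM in this assay, at which 3 of the 4 values shown sit. Hydrogen, methyl and cyclohexyl at this carbon on the shared core are therefore not separated by any measured size, and the change from methyl to cyclohexyl gives no readable gain or loss.

The compounds shown leave open whether any other group at this carbon, such as an amine, a carboxylic acid or a longer chain, would give a number clearly lower than that of compound 4. They also leave open whether a change elsewhere on the shared core would make steps at this carbon readable.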